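This account rests on a few compounds, and the source may have more. Where it says the series, first, only, none or still open, it means among the compounds named here.

Measured so far:
compound 1, `Cn1c(=O)c(S(=O)(=O)c2ccc(F)cc2F)cc2cnc(Nc3cccc4[nH]ccc34)nc21`, 1500 nM
compound 2, `Cn1c(=O)c(S(=O)(=O)c2ccc(C(=O)O)cc2)cc2cnc(Nc3ccc4[nH]ccc4c3)nc21`, 5000 nM
compound 3, `Cn1c(=O)c(S(=O)(=O)c2ccccc2)cc2cnc(Nc3ccc4ncccc4c3)nc21`, 100000 nM

All three compounds share one core and were tested in a functional assay on K562 cells (Homo sapiens) for inhibition, read by trypan blue exclusion, with a stated time of 72 h; on this read-out higher numbers stand for weaker inhibition and lower numbers for stronger inhibition. Compound 2 gives 5000 nM, the second highest of the three numbers: compound 1 gives a lower number, 1500 nM, while compound 3 gives a far higher one, 100000 nM. Compound 2 thus sits between them, closer to compound 1. Going by the values given here, no two measured compounds differ in only one place, so no single structural change can be sized from these numbers alone.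

Compound 4, `Cn1c(=O)c(S(=O)(=O)c2ccc(Cl)cc2Cl)cc2cnc(Nc3ccc4[nH]ccc4c3)nc21`, has not yet been measured. It differs from compound 2 in one place: 2,4-dichlorophenyl in place of 4-carboxyphenyl on a sulfonyl sulfur. The hydrogen-bond donor and the hydrogen-bond acceptor of the 4-carboxyphenyl are gone, and two chlorines arrive. Among the compounds with values here, no measured pair shows what this change does, so its direction is uncertain; a moderate step seems more likely than a large one. Compound 4 is therefore expected to give 2500 nM, with a range from 600 nM to 12000 nM. This corresponds to an expected step of a 2.0-fold lower number from compound 2 to compound 4 (0.30 log units; within the scatter), toward a somewhat lower number, of a size close to the edge of the scatter.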

Compound 4, half-maximal inhibitory concentration: 1000 nM
Compound 4: middle estimate off by 2.5-fold (0.40 log units), on the high side; measured number inside the range.
By their numbers in this assay, from the lowest: compounds 4 and 1 (each within the scatter of the next); then compound 2; then compound 3.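

In this assay, going by these compounds alone, the group on the sulfonyl sulfur makes a real difference: putting 2,4-dichlorophenyl in place of 4-carboxyphenyl gives a 5.0-fold lower number from compound 2 to compound 4 (0.70 log units; beyond the scatter), the first single change here whose size can be read. Compound 4 has neither the hydrogen-bond donor nor the hydrogen-bond acceptor of the 4-carboxyphenyl, so neither is required for a number this low on the shared core. No measurement on hand explains this step.

From the compounds shown here alone, this one swap removes the carboxylic acid and brings in two chlorines together, so the share of each remains unknown. Also open, going by these compounds, is how the same core would fare with a phenyl ring carrying a single chlorine, or with an amine in place of the carboxylic acid.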